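The compounds below may be only part of what the source reports. "The series", "measured", "known", "first", "only" and "open" are said of these compounds alone.

Measured so far:

compound 1, `CC(=O)c1ccccc1NC(=O)N[C@H](C)c1ccccc1`: 95%
compound 2, `CC(=O)c1cccc(NC(=O)N[C@H](C)c2ccccc2)c1`: 88%
compound 3, `C[C@@H](NC(=O)Nc1ccccc1F)c1ccccc1`: 95%

All three were run in an ADME assay on the whole organism with Oryza sativa as the target, tested at 1 uM; a lower number here means a stronger effect, a higher number a weaker effect of the compound at the concentration tested. Compound 1 gives 95% and compound 3 gives 95%; the step between them, no change at the digits printed from compound 1 to compound 3 (within the scatter), is the change (fluoro in place of acetyl on an aromatic carbon). Compound 2 gives 88%, and the gaps from compound 2 to compound 1 and to compound 3 both lie within the scatter, so nothing separates the three in this assay. Compound 1 and compound 2 have the same atoms joined differently; the difference between the two cores is not broken down here.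

Compound 4, `C[C@@H](NC(=O)Nc1cccc(F)c1)c1ccccc1`, has not yet been measured in this assay. It differs from compound 2 by fluoro in place of acetyl on an aromatic carbon. Within the data shown here, this is the same kind of change as the one from compound 1 to compound 3, but not the same change: in compound 3 the fluoro stands ortho to a large group, whereas in compound 4 it stands meta to a large group.

Because no change at the digits printed from compound 1 to compound 3 (within the scatter) shows no change within the scatter for this kind of change, the step from compound 2 to compound 4 is expected to be a number 1 percentage points higher from compound 2 to compound 4 (within the scatter). Compound 4 is therefore estimated at 89% in this assay, within an expected range of 78% to 97%. Only the two compounds carrying the change support this expectation.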

Compound 4, a percentage reported as activity, at one concentration (the size of the read-out at that concentration, not a potency): 95%
Estimate against measurement, compound 4: 6 percentage points below, and the stated range covers the measured number.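

In this assay fluoro in place of acetyl on an aromatic carbon can now be read on two cores, and the new step, with the fluoro meta to a large group, is a number 7 percentage points higher from compound 2 to compound 4 (within the scatter) on the core of compound 2. Set beside the earlier step, the change reads the same on both cores, with no difference between them that rises above the noise of the measurement: the same change on two cores in this assay, no change at the digits printed (within the scatter) from compound 1 to compound 3 and a number 7 percentage points higher (within the scatter) from compound 2 to compound 4, 7 percentage points apart, within the scatter of two such steps. This shows that the change carries from one core to the other without a detectable difference in this pair, but neither step stands out from the scatter, so the agreement is one of two null results and shows no measurable effect of the change on either core, nor any rule for other cores in the series.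

From the compounds shown here alone, only acetyl and fluoro appear on the aromatic ring in these compounds, so it remains open whether a different group there, such as an amine, a carboxylic acid or a longer chain, would give a step beyond the scatter. Going by these compounds, it also remains open whether fluoro in place of acetyl would read alike on a core where the starting number lies elsewhere in the range of this read-out.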